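Amide substituent change on the isobutyl pyrazole carboxamide

The compounds below may be only part of what the source reports. "The series", "measured", "known", "first", "only" and "open" are said of these compounds alone.

Two compounds of the series have a number in a toxicity assay on HepG2 2.2.15 cells (Homo sapiens) for cytotoxicity, read by CCK-8 assay, with a stated time of 8 days (a lower number here means that less compound is tolerated, a higher number that more compound is tolerated), so far. Compound 1 `CCOC(=O)c1cn(-c2cccc(OC)c2)nc1CC(C)C` gives 70500 nM there, and compound 2 `CC(C)Cc1nn(-c2nccs2)cc1C(=O)Nc1ccc(F)cc1` gives 83700 nM in this assay; the two values lie within the usual scatter of each other, so neither compound can be placed above the other.

Compound 3 `CC(C)Cc1nn(-c2nccs2)cc1C(=O)NCc1ccccc1F` differs from compound 2 in one place: 2-fluorobenzyl in place of 4-fluorophenyl on an amide-type nitrogen. For the measured compounds named here, no step between measured compounds touches this position, so no direction can be read from the data. The step from compound 2 to compound 3 is expected to stay within the scatter, a 1.0-fold lower number from compound 2 to compound 3 (0.02 log units; within the scatter). Compound 3 is thus estimated at 80000 nM in this assay, with a range from 40000 nM to 160000 nM.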

Compound 3, half-maximal cytotoxic concentration: > 100000 nM
Compound 3 was reported as a limit; the forecaster's own chance of this, stated with the estimate: 20%; middle value at least 1.2-fold (0.09 log units) away from the limit.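

Compound 3 gives > 100000 nM in this assay and that value is a limit, not a number. For the compounds shown here, the change at the amide-type nitrogen gives an at least 1.1-fold higher number from compound 2 to compound 3 (0.07 log units; that floor lies within the scatter) and so gives the first reading at this position: 2-fluorobenzyl in place of 4-fluorophenyl brings no lower number, while the size of any rise stays unknown.

The shown pair does not separate the extra carbon from the different fluorine placement. From the compounds shown here alone, whether a carboxylic acid or an amine on this aryl ring, or a longer chain on this nitrogen, would lower the number remains open.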